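Swapping the Amide Substituent: Expected Effect on Clearance

The compounds below may be only part of what the source reports. "The series", "measured", "known", "first", "only" and "open" are said of these compounds alone.

Among the compounds with values here, compound 2 `O=C(CCSc1nc2cc(Cl)ccc2o1)N1CCS(=O)(=O)C1` is the only compound here with a number: in an ADME assay on microsomes from liver (Mus musculus) for metabolic stability, read by LC-MS, using NADPH, with a stated time of 45 min, tested at 0.5 uM (on this read-out lower numbers stand for slow clearance and higher numbers for fast clearance), compound 2 gives 8.9 mL/min/g. Within the data shown here, compound 1 `O=C(CCSc1nc2cc(Cl)ccc2o1)NC1CCCC1` was also tested, but in this assay compound 1 gives "not determined" (no result reported), so no comparison between measured compounds can be drawn. The next compound, compound 3 `CN(C)C(=O)CCSc1nc2cc(Cl)ccc2o1`, differs from compound 2 in one place: dimethylamino in place of 1,1-dioxo-1,3-thiazolidin-3-yl on a carbonyl carbon. Among the measured compounds shown here, with no measured step to lean on, the expectation is a moderate rise in clearance, a 2.2-fold higher number from compound 2 to compound 3 (0.35 log units; beyond the scatter), beyond the usual scatter. Compound 3 is therefore estimated at 20 mL/min/g, within a range from 8 mL/min/g to 50 mL/min/g.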

Compound 3, intrinsic clearance in a liver preparation (reported as CLH), per the amount of preparation that the assay uses: 41.8 mL/min/g
Compound 3: middle estimate off by 2.1-fold (0.32 log units), on the low side; measured number inside the range.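

Changing only the group on the carbonyl carbon, with the rest of the molecule the same, moves the result in this assay by a 4.7-fold higher number from compound 2 to compound 3 (0.67 log units; beyond the scatter), so this position clearly affects the clearance read-out. Of this pair, the compound with 1,1-dioxo-1,3-thiazolidin-3-yl has the lower clearance. No measurement here explains the difference.

The compounds shown leave open whether the ring as such or the atoms in it account for this step. A pyrrolidine or morpholine amide at the same place would help separate the two.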